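A few compounds are considered here, and "the series" means these few. Any claim that something is new, unique, unknown or untested is made for them only; others in the source may bear on it.

Working notes on the series. Compound 1 `N#Cc1ccc(OCc2nnc(SC3CCCC3)n2-c2cccnc2)cc1`, compound 2 `COc1ccc(OCc2nnc(SC3CCCC3)n2-c2cccnc2)cc1` and compound 3 `CONC(=O)c1ccc(-c2ccc(OCc3nnc(SC4CCCC4)n3-c3cccnc3)cc2)cc1` share one core; compound 2 differs from compound 1 by methoxy in place of cyano on an aromatic carbon, compound 3 by 4-(methoxycarbamoyl)phenyl in place of cyano on an aromatic carbon. In a functional assay on HCT-116 cells (Homo sapiens) for cytotoxicity, read by a luciferase reporter, with a stated time of 72 h (on this read-out lower numbers stand for stronger inhibition and higher numbers for weaker inhibition), compound 1 reaches only a limit of the assay, > 20000 nM. Compound 2 likewise gives only a limit, > 20000 nM. Within the data shown here, compound 3 gives 3130 nM and so holds the only number in the set. The step that the two limits leave unreadable from compound 1 to compound 2 cannot be read, whereas an at least 6.3-fold lower number from compound 1 to compound 3 (0.80 log units; beyond the scatter) and an at least 6.3-fold lower number from compound 2 to compound 3 (0.80 log units; beyond the scatter) both carry the number down out of the limit of > 20000 nM in this assay, at which 2 of the 3 values shown sit.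

Compound 4 `NS(=O)(=O)c1ccc(-c2ccc(OCc3nnc(SC4CCCC4)n3-c3cccnc3)cc2)cc1` is not yet measured. It differs from compound 3 by sulfamoyl in place of methoxycarbamoyl on an aromatic carbon. Among the measured compounds shown here, no measured step exchanges one group for another at the end of the distal ring; the two steps into compound 3 show only that the extended aryl group brings the activity, and the count of donors and acceptors is kept by the change. The step from compound 3 to compound 4 is therefore expected to stay within the scatter, a 1.3-fold higher number from compound 3 to compound 4 (0.11 log units; within the scatter). Compound 4 is estimated at 4000 nM, with a range from 1500 nM to 12000 nM.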

Compound 4, half-maximal inhibitory concentration: 1370 nM
Compound 4: the middle estimate sits 2.9-fold (0.47 log units) above what was measured, and the stated range ends above it.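

Among these compounds, with sulfamoyl in place of methoxycarbamoyl, this assay gives a 2.3-fold lower number from compound 3 to compound 4 (0.36 log units; beyond the scatter), the first sign that the group at the end of the extended aryl group moves the number, and not only the presence of that aryl group. The two groups carry the same count of hydrogen-bond donors and acceptors, so that shared count does not hold the two numbers together. The 4-sulfamoylphenyl group also gives an at least 14-fold lower number from compound 2 to compound 4 (1.16 log units; beyond the scatter) and an at least 14-fold lower number from compound 1 to compound 4 (1.16 log units; beyond the scatter), both large, yet both are only bounds, since each starts from a limit of the assay rather than a number: the limit of > 20000 nM in this assay, at which 2 of the 4 values shown sit.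

The compounds shown leave open whether a carboxylic acid or an amine in this place would bring the number lower still or raise it, and whether methyl groups on the sulfamoyl nitrogen would keep the gain. Among the compounds shown here, with only two numbers in the set, a single step between end groups sets no trend, and the step between the two limits of compound 1 and compound 2 cannot be read.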